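Hexyl for bromophenyl in an ecdysone agonist series

This account rests on a few compounds, and the source may have more. Where it says the series, first, only, none or still open, it means among the compounds named here.

The set begins with compound 1 `CC(C)(C)N(NC(=O)c1ccccc1)C(=O)c1ccccc1F`, which in an assay on cells for agonist activity at ecdysone receptor (Bombyx mori), read by a luciferase reporter, with a stated time of 24 h (on this read-out lower numbers stand for an effect already at smaller amounts and higher numbers for an effect only at larger amounts of compound), gives 309 nM. Compound 2 `CC(C)(C)N(NC(=O)c1cccc(Br)c1)C(=O)c1ccccc1Cl` gives 191 nM, the lowest of the three numbers, though its gap to compound 1 lies within the scatter. Compound 3 `Cc1cc(C)cc(C(=O)NN(C(=O)CCC(C)C)C(C)(C)C)c1` stands far away and gives 14500 nM; it differs from compound 2 in more than one place, so the two values are only set side by side.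

Compound 4 `CCCCCCC(=O)NN(C(=O)c1ccccc1Cl)C(C)(C)C` is not yet measured. The change from compound 2 is hexyl in place of 3-bromophenyl on a carbonyl carbon. Within the data shown here, no single step between measured compounds shows this change on its own. Among the measured compounds shown here, compound 3, the only measured compound with a chain rather than an aromatic ring on that carbonyl carbon, is weak, so a clear weakening is expected in this assay, estimated as a 26-fold higher number from compound 2 to compound 4 (1.42 log units; beyond the scatter). Compound 4 is therefore expected at about 5000 nM, between 1000 nM and 30000 nM, because compound 3 gives 14500 nM.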

Compound 4, half-maximal effective concentration: 741 nM
The estimate for compound 4 lay 6.7-fold (0.83 log units) above the measured number; measured number below the stated range.
By their numbers in this assay, from the lowest: compounds 2 and 1 (each within the scatter of the next); then compound 4; then compound 3.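

Hexyl in place of 3-bromophenyl on a carbonyl carbon gives a 3.9-fold higher number from compound 2 to compound 4 (0.59 log units; beyond the scatter) in this assay, the first reading at this position in which only one place changes. The step is modest, though beyond the scatter, and compound 4 gives 741 nM with no ring at all on this carbonyl carbon, so for this pair the aromatic ring can be replaced by an open chain at a moderate cost. Nothing available here accounts for the size of this step.

The compounds shown leave open whether a cyclohexyl ring, a benzyl group or a longer chain such as octyl on this carbonyl carbon would come closer to compound 2. They also leave open whether the same change would give a step of similar size in another compound of the series.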